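A few compounds are considered here, and "the series" means these few. Any claim that something is new, unique, unknown or untested is made for them only; others in the source may bear on it.

Compound 1, `O=C(O)c1ccc(/N=C/c2cc3ccccc3[nH]c2=O)cc1`, in a functional assay, read by spectrophotometry, with a stated time of 5 min; a higher number here means a weaker inhibitor, a lower number a stronger inhibitor: 381000 nM
Compound 2, `NS(=O)(=O)CC(=O)N/N=C/c1cc2ccccc2[nH]c1=O`, in this assay: 256000 nM

Both measured compounds share the same core and both inhibit only weakly in this assay. Compound 2 shows the lower of the numbers measured, but its nearest neighbour, compound 1, gives a number that is higher by an amount within the usual scatter, so no order between the two can be claimed on this evidence.

Compound 3, `O=c1[nH]c2ccccc2cc1/C=N/Nc1ccccc1`, keeps the core of compound 2 and differs from it in one place: phenyl in place of (sulfamoylmethyl)carbonyl on an amine nitrogen. Among the measured compounds shown here, no measured pair shows the effect of this change, so there is nothing to set the size of the step from. With compound 1 and compound 2 both sitting at the weak end of this assay despite carrying different groups, the expectation is that compound 3 stays in the same weak region, and the step from compound 2 is expected not to exceed the scatter, a 1.2-fold lower number from compound 2 to compound 3 (0.07 log units; within the scatter). On that basis compound 3 is estimated to give 220000 nM in this assay, with a range from 60000 nM to 700000 nM.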

Compound 3, half-maximal inhibitory concentration: 306000 nM
Compound 3: middle estimate off by 1.4-fold (0.14 log units), on the low side; the measured number falls inside the stated range.
By their numbers in this assay, from the lowest: compounds 2, 3 and 1 (each within the scatter of the next).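

Among the compounds shown here, on an amine nitrogen of the shared core, phenyl in place of (sulfamoylmethyl)carbonyl gives a 1.2-fold higher number from compound 2 to compound 3 (0.08 log units; within the scatter) in this assay and so provides the first measured pair at this position. The exchange replaces a group with no ring, carrying hydrogen-bond donor and acceptor atoms, with a six-membered aromatic ring of carbon only that carries neither, yet the two numbers cannot be told apart. In this one pair, then, these differences in ring content and in hydrogen-bond donors and acceptors leave no readable mark on the result, and no measurement is available that would offer a reason for this.

With only this one exchange at the position, the compounds shown leave open whether any group there can move the number beyond the scatter and out of the weak region. A phenyl ring bearing a carboxylic acid or a chlorine atom, or a longer alkyl chain ending in an amine, would test this position in ways that neither compound 2 nor compound 3 can.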